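A few compounds are considered here, and "the series" means these few. Any claim that something is new, unique, unknown or untested is made for them only; others in the source may bear on it.

Measured compounds:
- compound 1 `CC(C)N[C@H](C(=O)Nc1cc2cc[nH]c(=O)c2cc1Cl)C1CCCCC1`: 190 nM in a functional assay (aorta) with Rattus norvegicus as the target; a lower number here means that less compound is needed, a higher number that more compound is needed for the effect
- compound 2 `CC(C)(C)C[C@@H](N)C(=O)Nc1cc2cc[nH]c(=O)c2cc1Cl`: "not determined" (no result reported) in this assay
- compound 3 `CN(C)[C@H]1CC[C@@H](C(=O)Nc2cc3cc[nH]c(=O)c3cc2Cl)CC1`: "not determined" (no result reported) in this assay

Compound 2 carries no number in this assay; it is one of two entries in the series without a result, compound 3 being the other. Among the compounds with values here, the only number in hand belongs to compound 1, which shares the core but differs from compound 2 in more than one place, so no single step can be read off between them.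

Compound 4 `CC(C)C[C@@H](N)C(=O)Nc1cc2cc[nH]c(=O)c2cc1Cl` is the next entry to be measured. It differs from compound 2 by hydrogen in place of methyl on a saturated chain carbon bound to three saturated chain carbons, read one bond further out as tert-butyl to isopropyl or neopentyl to isobutyl. With compound 2 unmeasured, the step cannot be anchored; the expectation for a change of this size is a shift in this assay of no more than the usual scatter, with no direction favoured. Taking compound 1 as the only reference point, compound 4 is estimated at 400 nM, within a range of 80 nM to 2000 nM.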

Compound 4, half-maximal effective concentration: 700 nM
Compound 4: the middle estimate sits 1.8-fold (0.24 log units) below what was measured; the range from low to high includes it.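

No new step can be read from compound 4: compound 2 carries no single number in this assay, and compound 1 differs from compound 4 in more than one place. From the compounds shown here alone, the effect of going from tert-butyl to isopropyl on the read-out stays open. No evidence bearing on this result is available.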